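This account rests on a few compounds, and the source may have more. Where it says the series, first, only, none or still open, it means among the compounds named here.

Compound 1 `N#CC1=C(N)Oc2c(c3nc4ccccc4nc3c3ccccc23)C12C(=O)N(Cc1cnnn1-c1ccc(N)cc1)c1ccccc12` gives 45200 nM in a functional assay on HCT-116 cells (Homo sapiens) for antiproliferative activity, read by MTT assay, with a stated time of 48 h; on this read-out lower numbers stand for stronger inhibition and higher numbers for weaker inhibition.
Compound 2 `N#CC1=C(N)Oc2c(c3nc4ccccc4nc3c3ccccc23)C12C(=O)N(Cc1cnnn1-c1cc(Cl)ccc1Cl)c1ccccc12` gives > 50000 nM, a limit of the assay.
Compound 3 `N#CC1=C(N)Oc2c(N)cc3nc4ccccc4nc3c2C12C(=O)N(Cc1cnnn1-c1ccc(F)cc1)c1ccccc12` gives > 50000 nM, likewise a limit of the assay.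

Compound 3 thus stands only at a limit in this assay, with no number of its own, a position it shares with compound 2, as the limit of > 50000 nM in this assay, at which 2 of the 3 values shown sit, shows. Compound 4 `N#CC1=C(N)Oc2c(N)cc3nc4ccccc4nc3c2C12C(=O)N(Cc1cnnn1-c1ccc([N+](=O)[O-])cc1[N+](=O)[O-])c1ccccc12` differs from compound 3 in one place: 2,4-dinitrophenyl in place of 4-fluorophenyl on an aromatic nitrogen. Going by the values given here, the one measured step of a similar kind, a change of the aryl group on the aromatic nitrogen, is an at least 1.1-fold higher number from compound 1 to compound 2 (0.04 log units; that floor lies within the scatter), which ended at the limit. With compound 3 already at the limit > 50000 nM, no step beyond the scatter is expected in this assay. Compound 4 is therefore expected near 50000 nM, between 20000 nM and 100000 nM, most likely again only as a limit. The expected step of a number no higher from compound 3 to compound 4 (the limit leaves the size open) is estimated as essentially none.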

Compound 4, half-maximal inhibitory concentration: 23900 nM
The estimate for compound 4 lay 2.1-fold (0.32 log units) above the measured number, and the stated range covers the measured number.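

In this assay, the aryl group on the aromatic nitrogen can bring the core of compound 3 off the limit: the change gives an at least 2.0-fold lower number from compound 3 to compound 4 (0.32 log units; beyond the scatter) and is the first step at this position shown to lie beyond the scatter. The earlier step on the other core, an at least 1.1-fold higher number from compound 1 to compound 2 (0.04 log units; that floor lies within the scatter), did not show this. From the compounds shown here alone, the full size of the new step stays open, as compound 3 stands only at a limit: the limit of > 50000 nM in this assay, at which 2 of the 4 values shown sit.

The compounds shown leave open whether a single nitro group, a methoxy group or a carboxylic acid on the phenyl ring would also shift the number on this core. They also leave open whether 2,4-dinitrophenyl would do so on the core of compound 1.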